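The source may report more compounds than this note shows. Statements on the series, on what has been measured and on what is new or still open speak of the compounds shown alone.

Measured compounds in an assay on isolated protein for inhibition of malate dehydrogenase, mitochondrial (Sus scrofa), with stated times of 45 min and 30 min; on this read-out lower numbers stand for stronger inhibition and higher numbers for weaker inhibition:
- compound 1 `O=S(=O)(Nc1ccc2oc(-c3ccccc3)nc2c1)c1ccc(O)cc1` gives > 63000 nM, which is a limit of the assay, not a number.
- compound 2 `COc1cccc(S(=O)(=O)Nc2ccc3oc(-c4ccccc4)nc3c2)c1` gives > 63000 nM, again a limit of the assay.
- compound 3 `Cc1ccc(S(=O)(=O)Nc2ccc3oc(-c4ccccc4)nc3c2)cc1` gives > 63000 nM, once more a limit of the assay.

All three measured compounds share the same core and differ only in the aromatic group on the sulfonyl sulfur. Compound 3 stands at the limit of this assay, as the limit of > 63000 nM in this assay, at which 3 of the 3 values shown sit, shows; none of the three measurements yields a number, so no ranking among them can be read.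

The unmeasured compound 4 `COc1ccc(Cl)cc1S(=O)(=O)Nc1ccc2oc(-c3ccccc3)nc2c1` differs from compound 3 in one place: 5-chloro-2-methoxyphenyl in place of 4-methylphenyl on a sulfonyl sulfur.

The measured steps that bear on this change all involve swapping one aromatic group for another on the sulfonyl sulfur. The step that the two limits leave unreadable from compound 1 to compound 2, the step that the two limits leave unreadable from compound 1 to compound 3 and the step that the two limits leave unreadable from compound 2 to compound 3 are all unreadable, since both ends sit at the limit. Among the measured compounds shown here, they therefore give no size and no direction for the step to compound 4; they only show that three different aromatic groups in this position all leave the compound without measurable inhibition.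

On this basis compound 4 is expected to stay at or near the limit as well, with an estimated step that the limit leaves unreadable from compound 3 to compound 4. Compound 4 is estimated at 90000 nM, within a range from 20000 nM to 400000 nM.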

Compound 4, half-maximal inhibitory concentration: > 63000 nM
Compound 4: no number, only a limit (the forecaster's own chance of this, stated with the estimate: 85%); the middle value does not contradict the limit.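

In this assay compound 4 gives > 63000 nM as a limit of the assay, not a number. Among the compounds shown here, no step between compound 4 and compound 1, compound 2 or compound 3 can be read, as all four stop at the same point: the limit of > 63000 nM in this assay, at which 4 of the 4 values shown sit.

The compounds shown leave open how weak each one truly is, and whether any aromatic group on the sulfonyl sulfur can give a measurable inhibition.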